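The compounds below may be only part of what the source reports. "The series", "measured", "known", "first", "only" and "open" are said of these compounds alone.

Working notes on the series, read in a functional assay on K562 cells (Homo sapiens) for inhibition, read by trypan blue exclusion, with a stated time of 72 h; on this read-out higher numbers stand for weaker inhibition and lower numbers for stronger inhibition. Compound 1 `Cc1ccc(S(=O)(=O)c2cc3cnc(Nc4ccc5[nH]ccc5c4)nc3n(C)c2=O)cc1` gives 750 nM, compound 2 `Cn1c(=O)c(S(=O)(=O)c2ccc(Br)cc2)cc2cnc(Nc3ccc4[nH]ccc4c3)nc21` gives 5000 nM, and compound 3 `Cn1c(=O)c(S(=O)(=O)Nc2ccc(F)cc2F)cc2cnc(Nc3ccc4[nH]ccc4c3)nc21` gives 5000 nM. Compound 3 thus stands level with compound 2, and these two share the highest number of the three.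

Compound 4 `Cn1c(=O)c(S(=O)(=O)c2ccc(F)cc2N)cc2cnc(Nc3ccc4[nH]ccc4c3)nc21` changes the group on the sulfonyl sulfur of compound 3: 2-amino-4-fluorophenyl in place of (2,4-difluorophenyl)amino on a sulfonyl sulfur.

Among the compounds with values here, three measured steps bear on this change. Two concern the same place and run toward the group that compound 3 carries: a 6.7-fold higher number from compound 1 to compound 3 (0.82 log units; beyond the scatter), and no change at the digits printed from compound 2 to compound 3 (within the scatter). The third shows that the two compounds with a phenyl ring on the sulfonyl sulfur do not agree with each other: a 6.7-fold higher number from compound 1 to compound 2 (0.82 log units; beyond the scatter). Compound 4 also has a phenyl ring on that sulfur, so its number could fall anywhere from near compound 1 at 750 nM to near compound 2 at 5000 nM. Within the data shown here, no measured compound carries 2-amino-4-fluorophenyl, so this comparison remains indirect.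

A modest move toward a lower number in this assay is therefore expected: a 2.5-fold lower number from compound 3 to compound 4 (0.40 log units; beyond the scatter). The estimated value for compound 4 is 2000 nM, with an expected range from 600 nM to 6000 nM.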

Compound 4, half-maximal inhibitory concentration: 2000 nM
Estimate against measurement, compound 4: no gap at the digits printed; low and high end bracket the measured number.
By their numbers in this assay, from the lowest: compound 1; then compound 4; then compounds 2 and 3 (each within the scatter of the next).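

In this assay, 2-amino-4-fluorophenyl on the sulfonyl sulfur gives a 2.5-fold lower number from compound 3 to compound 4 (0.40 log units; beyond the scatter) and, against the 4-bromophenyl group, a 2.5-fold lower number from compound 2 to compound 4 (0.40 log units; beyond the scatter) in the same direction, so the level shared by compounds 2 and 3 is not a ceiling that every change at this position leaves untouched. The 4-methylphenyl group still holds the lowest number of the four, with a 2.7-fold higher number from compound 1 to compound 4 (0.43 log units; beyond the scatter) on the way up, which places compound 4 between compound 1 and the pair of compounds 2 and 3, and the three compounds with a phenyl ring directly on the sulfonyl sulfur now sit at three separate levels. These numbers show the size of the differences only, and nothing on hand accounts for them.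

Open, as far as these compounds go, is how the step divides between the amine and the fluorine on the ring, a question that 2-aminophenyl or 4-fluorophenyl on the sulfonyl sulfur would address. Also open, from the compounds shown here alone, is whether the 4-methyl group and the 2-amino group add up or cancel in a single 2-amino-4-methylphenyl group, and how a carboxylic acid on the ring would read here.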